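Ethoxy for ethylsulfanyl on compound 1

The source may report more compounds than this note shows. Statements on the series, on what has been measured and on what is new or still open speak of the compounds shown alone.

- compound 1 `CCSc1ccc(C2C(O)C(=O)N2c2cc(OC)c(OC)c(OC)c2)cc1`: 12 nM
- compound 2 `CCSc1ccc(C2CC(=O)N2c2cc(OC)c(OC)c(OC)c2)cc1`: 311 nM
- compound 3 `C=CC1C(=O)N(c2cc(OC)c(OC)c(OC)c2)C1c1ccc(SCC)cc1`: 257 nM

In a functional assay on HT-29 cells (Homo sapiens) for inhibition, read by sulforhodamine B assay, with a stated time of 72 h (on this read-out higher numbers stand for weaker inhibition and lower numbers for stronger inhibition), compound 1 gives the lowest number of the three at 12 nM. Both of its measured steps are large and beyond the scatter: a 26-fold higher number from compound 1 to compound 2 (1.41 log units; beyond the scatter) and a 21-fold higher number from compound 1 to compound 3 (1.33 log units; beyond the scatter). By contrast, a 1.2-fold lower number from compound 2 to compound 3 (0.08 log units; within the scatter) stays within the scatter. All three steps concern one saturated ring carbon.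

Compound 4 `CCOc1ccc(C2C(O)C(=O)N2c2cc(OC)c(OC)c(OC)c2)cc1` keeps the hydroxy of compound 1 and differs elsewhere: ethoxy in place of ethylsulfanyl on an aromatic carbon. This is ethoxy in place of ethylsulfanyl on an aromatic carbon, para to a large group. Among the measured compounds shown here, no measured step covers this place, so the three steps give no direct measure of its size. Since the hydroxy stays, the large losses seen on removing it are not expected to carry over. A small change in this assay is expected, probably within the scatter, and any shift is more likely towards a higher number. The expected change is a 1.7-fold higher number from compound 1 to compound 4 (0.22 log units; within the scatter). For compound 4 the estimate is 20 nM, with an expected range from 6 nM to 80 nM.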

Compound 4, half-maximal inhibitory concentration: 15 nM
Beside the measured number, compound 4's estimate is 1.3-fold (0.12 log units) above it, and the stated range covers the measured number.
By their numbers in this assay, from the lowest: compounds 1 and 4 (each within the scatter of the next); then compounds 3 and 2 (each within the scatter of the next).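

In this assay, among the compounds shown here, ethoxy in place of ethylsulfanyl on the aromatic carbon gives a 1.3-fold higher number from compound 1 to compound 4 (0.10 log units; within the scatter), the first measure at this position, which the earlier steps on the saturated ring carbon did not reach. With the hydroxy kept, the sulfur of compound 1 is therefore not needed for a number at this level, at least in this one pair, as compound 4 cannot be told apart from compound 1. Nothing available here offers an explanation for this result.

The compounds shown leave open how a longer chain such as propoxy or an amine such as dimethylamino would behave at this position. From the compounds shown here alone, whether removing the hydroxy from compound 4 would cost as much as it does on compound 1 also stays open.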